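Solubility notes: benzyl to fluorobenzyl on the imide nitrogen

The source may hold more compounds than are shown below. What is called first, only, known or untested is meant among the compounds shown, and "the series" means these compounds.

Compound 1 `CCOC(=O)c1nc(C)c2c(c1N)C(=O)N(Cc1ccccc1)C2=O` gives < 5000 nM, which is a limit of the assay, not a number.
Compound 2 `CCCOC(=O)c1nc(C)c2c(c1N)C(=O)N(Cc1ccccc1)C2=O` gives < 5000 nM, also a limit of the assay.
Compound 3 `Cc1noc(-c2nc(C)c3c(c2N)C(=O)N(CC2CCOCC2)C3=O)n1` gives 5700 nM in a physicochemical assay for solubility, using the shake flask method, in simulated intestinal fluid, measured as kinetic solubility, with a stated time of 2 h, at 25 degrees C, at pH 6.5; on this read-out lower numbers stand for lower solubility and higher numbers for higher solubility.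
Compound 4 `Cc1noc(-c2nc(C)c3c(c2N)C(=O)N(Cc2ccccc2F)C3=O)n1` is not yet measured in this assay.

Among the measured compounds shown here, compound 3 stands as the only numerical value shown; the other two values are limits. For the measured compounds named here, the one measured step, a step that the two limits leave unreadable from compound 1 to compound 2, is unreadable for size, and it concerns the ester chain rather than the group on the amide-type nitrogen. Going by the values given here, no measured step therefore bears on the change from compound 3 to compound 4, (2-fluorophenyl in place of oxan-4-yl on a saturated chain carbon bound to an amide-type nitrogen in a ring).

What is available is the limit of < 5000 nM in this assay, at which 2 of the 3 values shown sit, which places compound 1 and compound 2, both carrying a benzyl group on the ring nitrogen, at the limit, while compound 3 with its (oxan-4-yl)methyl group sits just above it. Compound 4 carries a 2-fluorobenzyl group, closer to compound 1 and compound 2 in that position than to compound 3. The expectation for compound 4 is therefore a step of a 1.9-fold lower number from compound 3 to compound 4 (0.28 log units; within the scatter) downward in this assay, with a fair chance that only a limit is reported. The estimated solubility of compound 4 is 3000 nM, with a range from 700 nM to 9000 nM.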

Compound 4, solubility: < 5000 nM
Compound 4: only a limit was reported (the forecaster's own chance of this, stated with the estimate: 60%); the middle value does not contradict the limit.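

Among the compounds shown here, this is the first readable step at this position, on a saturated chain carbon bound to an amide-type nitrogen in a ring: in this assay 2-fluorophenyl in place of oxan-4-yl gives an at least 1.1-fold lower number from compound 3 to compound 4 (0.05 log units; that floor lies within the scatter) with the rest of the structure unchanged. The value of compound 4 is a limit, so the step is only a floor, and its true size could lie within the scatter or well beyond it. For the compounds shown here, compound 3 remains the only compound with a number, and the other compounds all sit at the limit: the limit of < 5000 nM in this assay, at which 3 of the 4 values shown sit.

The exchange replaces a non-aromatic ring holding one oxygen with an aromatic ring of carbon carrying one fluorine, and compound 3 and compound 4 alone cannot separate the contributions of the ring and the fluorine. On these data alone, how a plain phenyl, a piperidin-4-yl amine or a carboxylic acid in this place would read in this assay stays open, as does any number for compound 4 under the limit.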